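The compounds below may be only part of what the source reports. "The series", "measured", "known", "first", "only" and "open" are said of these compounds alone.

Series notes. In an assay on isolated protein (artery, Oryctolagus cuniculus) with Substance-P receptor (Homo sapiens) as the target (on this read-out lower numbers stand for tighter binding and higher numbers for weaker binding), compound 1 `O=C1CCC(CCN2CC(N3CCNCC3)C2)(c2ccc(Cl)c(Cl)c2)CN1Cc1ccccc1` gives 5.01 nM. Compound 2 `O=C1CCC(CCN2CC(N3CCC(O)C3)C2)(c2ccc(Cl)c(Cl)c2)CN1Cc1ccccc1` gives 2 nM in this assay, and compound 3 `O=C1CCC(CCN2CC(N3CCNCC3)C2)(c2ccc(Cl)c(Cl)c2)CN1CC1CC1` gives 12.6 nM. Compound 3 thus stands with the highest number of the three: the step of a 2.5-fold higher number from compound 1 to compound 3 (0.40 log units; beyond the scatter) lies beyond the scatter, and compound 2 sits further off still, with the lowest number of the set. Compound 4 `O=C(O)C1CCN(C2CN(CCC3(c4ccc(Cl)c(Cl)c4)CCC(=O)N(CC4CC4)C3)C2)CC1` carries the same cyclopropyl group as compound 3 and differs from it in one change only: 4-carboxypiperidin-1-yl in place of piperazin-1-yl on a saturated ring carbon. For the measured compounds named here, of the measured steps, only one bears on this change, since it alters the same group at the same place: a 2.5-fold lower number from compound 1 to compound 2 (0.40 log units; beyond the scatter), a modest gain. The group entering here is not the one that gave that gain, so its direction can only be read loosely; a modest step in this assay, leaning toward a lower number, is expected, a 1.6-fold lower number from compound 3 to compound 4 (0.20 log units; within the scatter). For compound 4 the estimate in this assay is 8 nM, with a range from 2.5 nM to 25 nM.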

Compound 4, dissociation constant: 0.398 nM
The estimate for compound 4 lay 20-fold (1.30 log units) above the measured number; measured number outside the range, below it.
By their numbers in this assay, from the lowest: compound 4; then compound 2; then compound 1; then compound 3.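

In this assay, for the compounds shown here, the saturated ring carbon of the four-membered ring now shows a much wider span than the earlier compounds gave: a 32-fold lower number from compound 3 to compound 4 (1.50 log units; beyond the scatter) is a large step, against the modest 2.5-fold lower number from compound 1 to compound 2 (0.40 log units; beyond the scatter) at the same place. The exchange of piperazin-1-yl for a group of 9 heavy atoms carrying a carboxylic acid thus moves the number far more than 3-hydroxypyrrolidin-1-yl did, and it does so toward tighter binding. Nothing at hand bears on why this change gives so large a step.

Going by these compounds, whether the step belongs to the carboxylic acid or to the piperidine ring stays open; a methyl ester, a primary amide or plain piperidin-1-yl at this place would separate the two. Also open, on these data alone, is whether 4-carboxypiperidin-1-yl gives a step of this size alongside the phenyl group of compound 1.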